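Chloro for hydroxy on the aryl ring of compound 3

The source may hold more compounds than are shown below. What is called first, only, known or untested is meant among the compounds shown, and "the series" means these compounds.

Three hydrazide-hydrazones sharing a naphthyloxyacetyl core have been measured in an ADME assay on HEL cells (Homo sapiens) for cytotoxicity; a higher number here means that more compound is tolerated, a lower number that less compound is tolerated. Compound 1 `C/C(=N\NC(=O)COc1cccc2ccccc12)c1ccc(C#N)cc1Br` gives 12.7 ug/mL in this assay. Compound 2 `O=C(COc1cccc2ccccc12)N/N=C/c1ccccc1Br` gives 100 ug/mL in this assay. Compound 3 `C/C(=N\NC(=O)COc1cccc2ccccc12)c1ccc(O)cc1` gives 11.1 ug/mL in this assay, the lowest of the three numbers, within the scatter of compound 1 and well apart from compound 2. Among the measured compounds shown here, the only single-point step recorded so far, a 1.1-fold lower number from compound 1 to compound 3 (0.06 log units; within the scatter), exchanged one whole aryl ring for another and left the number essentially where it was.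

Compound 4 `C/C(=N\NC(=O)COc1cccc2ccccc12)c1ccc(Cl)cc1` differs from compound 3 in one place: chloro in place of hydroxy on an aromatic carbon. For the measured compounds named here, no measured step exchanges a single substituent on this ring, so the closest guide is the step from compound 1, in which a far larger exchange on the same ring produced no movement beyond the scatter. On that basis compound 4 is expected to stay close to compound 3, with a 1.0-fold lower number from compound 3 to compound 4 (0.00 log units; within the scatter) as the estimated step and no change beyond the scatter. The value expected for compound 4 in this assay is 11 ug/mL, with a range from 5 ug/mL to 30 ug/mL.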

Compound 4, half-maximal cytotoxic concentration: 7.1 ug/mL
Compound 4: the middle estimate sits 1.5-fold (0.19 log units) above what was measured; the range from low to high includes it.
By their numbers in this assay, from the lowest: compounds 4, 3 and 1 (each within the scatter of the next); then compound 2.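

In this assay, among the compounds shown here, the first exchange of a single substituent on this ring, a 1.6-fold lower number from compound 3 to compound 4 (0.19 log units; within the scatter), stays within the scatter, although the hydroxy counts as a hydrogen-bond donor and acceptor and the chloro counts as neither. The wider exchange of 2-bromo-4-cyanophenyl for 4-chlorophenyl, a 1.8-fold lower number from compound 1 to compound 4 (0.25 log units; within the scatter), also stays within the scatter, so across compound 1, compound 3 and compound 4 neither a whole-ring exchange nor a single exchange at the position para to a large group moves the number beyond it. Nothing available here bears on what lies behind this flat reading.

For the compounds shown here, it remains open whether an amine, a carboxylic acid or a longer alkoxy chain at this same position would also stay within the scatter, since hydroxy and chloro are the only single groups compared there. Compound 2 gives 100 ug/mL and differs from each of the other compounds in more than one place, so which of its differences goes with its separate standing in this assay is left unsettled.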